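The source may report more compounds than this note shows. Statements on the series, on what has been measured and on what is new or still open speak of the compounds shown alone.

Working notes on the series in a functional assay on NCI-H226 cells (Homo sapiens) for inhibition, read by sulforhodamine B assay, with a stated time of 48 h; a higher number here means a weaker inhibitor of growth, a lower number a stronger inhibitor of growth.

Of the compounds shown here, three have numbers so far. Compound 1 `O=C(Nc1cccc(-n2cc(-c3ccncc3)c(-c3ccc(Cl)c(O)c3)n2)c1)Nc1cc(C(F)(F)F)cc(C(F)(F)F)c1` gives 1240 nM, the smallest number of the three, yet neither of the others stands apart from it beyond the scatter: compound 2 `COc1cc(-c2nn(-c3cccc(NC(=O)Nc4ccc(Cl)c(C(F)(F)F)c4)c3)cc2-c2ccncc2)ccc1Cl` gives 1820 nM, and compound 3 `COc1cc(-c2nn(-c3cccc(NC(=O)c4ccccc4)c3)cc2-c2ccncc2)ccc1Cl` gives 2350 nM. Among the measured compounds shown here, the only single-point step among the measured compounds is a 1.3-fold higher number from compound 2 to compound 3 (0.11 log units; within the scatter), which concerns the carbonyl end of the molecule and not the bis-trifluoromethyl ring of compound 1.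

Compound 4 `O=C(Nc1cccc(-n2cc(-c3ccncc3)c(-c3ccc(Cl)c(O)c3)n2)c1)Nc1cccc(C(F)(F)F)c1` is the next one to be measured. Relative to compound 1 the change is hydrogen in place of trifluoromethyl on an aromatic carbon. No measured step touches a trifluoromethyl group on that ring, so the expectation rests on the general flatness of the series, where every shown step falls within the scatter. A step of size a 1.5-fold higher number from compound 1 to compound 4 (0.16 log units; within the scatter) is therefore expected, with no direction beyond the scatter. Compound 4 is estimated at 1800 nM, between 800 nM and 4000 nM.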

Compound 4, concentration for 50% growth inhibition: 7350 nM
Beside the measured number, compound 4's estimate is 4.1-fold (0.61 log units) below it; the whole stated range lies below it.
By their numbers in this assay, from the lowest: compounds 1, 2 and 3 (each within the scatter of the next); then compound 4.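

Hydrogen in place of trifluoromethyl on this aromatic carbon gives a 5.9-fold higher number from compound 1 to compound 4 (0.77 log units; beyond the scatter) in this assay, the first step shown in the series that lies beyond the scatter. The series is therefore not flat at this position, meta to a trifluoromethyl group, even though the change at the carbonyl end, a 1.3-fold higher number from compound 2 to compound 3 (0.11 log units; within the scatter), stayed within the scatter. Nothing available explains the size of the step.

Going by these compounds, with only hydrogen and trifluoromethyl compared at this carbon, it stays open whether a methyl group, a nitrile or a tert-butyl group would keep the number close to that of compound 1 or move it towards that of compound 4. On these data alone, it also stays open whether the same change would give a step of similar size on the methoxy-bearing background of compound 2.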